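A few compounds are considered here, and "the series" means these few. Any claim that something is new, unique, unknown or untested is made for them only; others in the source may bear on it.

In an assay for inhibition of Polyunsaturated fatty acid 5-lipoxygenase (Homo sapiens), read by spectrophotometry, tested at 20 uM (on this read-out lower numbers stand for less inhibition and higher numbers for more inhibition at the one concentration tested (going by the name of the read-out)), compound 1 `O=C(/C=C/c1ccc(O)c(O)c1)N1CCCCC1` gives 55.2%, while compound 2 `CSc1ccc(/C=C/C=C/C(=O)N2CCCCC2)cc1` gives 11.8%, the lowest of the two numbers and a gap from compound 1 that lies beyond the usual scatter. Compound 3 `O=C(/C=C/C=C/c1ccc(OC2CCCC2)cc1)N1CCCCC1` differs from compound 2 in one place: cyclopentyloxy in place of methylsulfanyl on an aromatic carbon. Among the measured compounds shown here, no measured pair shows this particular change, so its effect is not known from the data at hand. A step from compound 2 to compound 3 of a number 3.2 percentage points higher from compound 2 to compound 3 (within the scatter) is expected, not clearly beyond the scatter in either direction. Compound 3 is therefore estimated at 15%, with a range from 0% to 35%.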

Compound 3, a percentage reported as inhibition, at one concentration (the size of the read-out at that concentration, not a potency): 16.1%
Compound 3: middle estimate off by 1.1 percentage points, on the low side; the range from low to high includes it.
By their numbers in this assay, from the lowest: compounds 2 and 3 (each within the scatter of the next); then compound 1.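

In this assay, replacing methylsulfanyl with cyclopentyloxy on the aromatic carbon gives a number 4.3 percentage points higher from compound 2 to compound 3 (within the scatter). At this position, then, a larger group carrying a five-membered ring of carbon leaves the read-out about where it was, so this change gives no clear gain or loss. No supporting measurement here accounts for this result. From the compounds shown here alone, whether an amine or a carboxylic acid on the same aromatic carbon would move the number beyond the scatter remains open.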